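The source may hold more compounds than are shown below. What is called first, only, known or untested is meant among the compounds shown, and "the series" means these compounds.

Compound 1 `NS(=O)(=O)c1ccccc1-c1cnc(C(=O)CCCCCCc2ccccc2)o1`: 1500 nM
Compound 2 `O=C(CCCCCCc1ccccc1)c1ncc(-c2ccc(O)cc2)o1`: 140 nM
Compound 3 `NS(=O)(=O)c1ccc(-c2cnc(C(=O)CCCCCCc3ccccc3)o2)cc1`: 10 nM

Of the compounds shown here, three have been tested in an assay (Rattus norvegicus) for inhibition of Fatty-acid amide hydrolase 1 (Homo sapiens); on this read-out higher numbers stand for weaker inhibition and lower numbers for stronger inhibition. Compound 2 stands second highest of the three numbers: compound 1 gives the higher value 1500 nM, while compound 3 gives the lower value 10 nM. Compound 4 `O=C(CCCCCCc1ccccc1)c1ncc(C(=O)C(F)(F)F)o1` has not yet been measured. It differs from compound 2 in one place: (trifluoromethyl)carbonyl in place of 4-hydroxyphenyl on an aromatic carbon.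

For the measured compounds named here, only one measured step touches this part of the shared core. Replacing hydroxy with sulfamoyl on an aromatic carbon gave a 14-fold lower number from compound 2 to compound 3 (1.15 log units; beyond the scatter), so the group at this position can move the number a long way. Compound 1 and compound 3 together show that moving the sulfamoyl group on the phenyl ring also matters, with compound 1 giving 1500 nM against compound 3 at 10 nM. Going by the values given here, no measured compound carries a (trifluoromethyl)carbonyl group or lacks the aromatic ring here, so the direction for compound 4 rests on a guess informed only by how sensitive this position proved to be. A modest step downward is expected, a 2.3-fold lower number from compound 2 to compound 4 (0.37 log units; beyond the scatter), with wide uncertainty. Compound 4 is estimated to give 60 nM in this assay, within a range from 12 nM to 300 nM.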

Compound 4, inhibition constant: 4 nM
The estimate for compound 4 lay 15-fold (1.18 log units) above the measured number, and the stated range ends above it.
By their numbers in this assay, from the lowest: compound 4; then compound 3; then compound 2; then compound 1.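

In this assay, the step of a 35-fold lower number from compound 2 to compound 4 (1.54 log units; beyond the scatter) is larger than the step from the hydroxy to the sulfamoyl compound, and it comes from a different kind of change. For the compounds shown here, compounds 1, 2 and 3 all carry a six-membered aromatic ring at this aromatic carbon, so they could show only that groups on that ring matter; compound 4 shows that the whole ring can be replaced by (trifluoromethyl)carbonyl, a group with no ring and no hydrogen-bond donor, and that the number still falls well beyond the scatter. No supporting measurement is available to explain why this exchange has such a large effect.

Three things change together in this step: the ring leaves, a carbonyl enters and three fluorine atoms enter, and the compounds shown do not separate their contributions. An acetyl group, which keeps the carbonyl without the fluorine atoms, or a trifluoromethyl group attached directly to this aromatic carbon, which keeps the fluorine atoms without the carbonyl, would help to show which part of the new group goes with the lower number.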